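A Larger Amine on the Aromatic Ring of Compound 2

The compounds below may be only part of what the source reports. "The series", "measured", "known", "first", "only" and "open" are said of these compounds alone.

Measured compounds:
compound 1 `CN(C)c1ccc(/C=C2\Oc3cc(O)cc(O)c3C2=O)cc1` — 5940 nM
compound 2 `COc1cc(O)c2c(c1)O/C(=C\c1ccc(N(C)C)cc1)C2=O` — 703 nM

Both compounds were tested in an assay on isolated protein for inhibition of Amine oxidase [flavin-containing] B (Homo sapiens), read by fluorescence and spectrophotometry, with a stated time of 30 min; a lower number here means a stronger inhibitor, a higher number a weaker inhibitor. For the measured compounds named here, of the two numbers, compound 2 has the lower one and is therefore the stronger inhibitor of the pair; its only neighbour is compound 1, and the single measured step, an 8.4-fold lower number from compound 1 to compound 2 (0.93 log units; beyond the scatter), came from a methyl in place of hydrogen on an oxygen on an aromatic ring.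

Compound 3 `COc1cc(O)c2c(c1)O/C(=C\c1ccc(N3CCCCC3)cc1)C2=O` differs from compound 2 in one place: piperidin-1-yl in place of dimethylamino on an aromatic carbon. Going by the values given here, no measured step touches this part of the structure; the only step on record concerns a different position, so it gives no direct guide to the size or direction of the change. In the absence of such a guide, the most reasonable expectation is a step no larger than the scatter of this assay, in either direction.

Compound 3 is therefore expected to give about 700 nM, within a range of 250 nM to 2000 nM. The expected step, a 1.0-fold lower number from compound 2 to compound 3 (0.00 log units; within the scatter), is thus estimated to be small.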

Compound 3, half-maximal inhibitory concentration: 226 nM
Beside the measured number, compound 3's estimate is 3.1-fold (0.49 log units) above it, outside the stated range (below it).
By their numbers in this assay, from the lowest: compound 3; then compound 2; then compound 1.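

The step of a 3.1-fold lower number from compound 2 to compound 3 (0.49 log units; beyond the scatter) in this assay shows that the group on this aromatic carbon, para to a large group, affects the result, since the change lies beyond the scatter of repeated measurements. This is new information. The earlier step concerned only a methyl in place of hydrogen on an oxygen elsewhere in the molecule. Piperidin-1-yl has more heavy atoms than dimethylamino and adds a six-membered non-aromatic ring, while the counts of hydrogen-bond donors and acceptors and the net charge stay the same, and no measurement here explains why the number differs.

The single swap changes the heavy-atom count and adds the ring together, so the compounds shown leave open which of these goes with the lower number; diethylamino, which has an open chain, and pyrrolidin-1-yl, which has a smaller ring, would help to pull the two apart. Also open, on these data alone, is whether piperidin-1-yl would give a step of similar size on the core of compound 1, and whether morpholin-4-yl, with an oxygen in the ring, would keep the lower number.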